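Swapping a Lysine Side Chain for a Carboxy Group

The source may hold more compounds than are shown below. What is called first, only, known or untested is meant among the compounds shown, and "the series" means these compounds.

Compound 3, `NCCCC[C@H](N)C(=O)O[C@H]1C[C@H](n2cc(F)c(=O)[nH]c2=O)O[C@@H]1CO`, gives 0.85 h in an ADME assay on a cell-free system (plasma, Homo sapiens) for metabolic stability; on this read-out higher numbers stand for a longer-lived compound and lower numbers for a shorter-lived compound.
Compound 1, `NCCCC[C@H](N)C(=O)OC[C@H]1O[C@@H](n2cc(F)c(=O)[nH]c2=O)C[C@@H]1OC(=O)[C@@H](N)CCCCN`, gives 0.492 h.
Compound 2, `CCOC(=O)CNC(=O)OCOC(=O)C(C)(C)Oc1ccc(Cl)cc1`, gives 0.0272 h.

Among these three numbers compound 3 sits within the scatter of compound 1: the step of a 1.7-fold higher number from compound 1 to compound 3 (0.24 log units; within the scatter) is too small to count as a real change. Both of these compounds stand far apart from compound 2, whose number is much lower than that of compound 3.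

Compound 4, `N[C@@H](CC(=O)O)C(=O)O[C@H]1C[C@H](n2cc(F)c(=O)[nH]c2=O)O[C@@H]1CO`, is the next compound in this series. It differs from compound 3 in one place: carboxy in place of 3-aminopropyl on a saturated chain carbon, two bonds along the chain from an amine nitrogen and a carbonyl carbon. In plain terms, the lysine-derived ester on the shared core is replaced by an aspartate-derived ester.

Within the data shown here, only one measured step is available, the one from compound 1 to compound 3, and it concerns a different change, the loss of a second ester on the core, not the exchange of one amino acid for another. Among the measured compounds shown here, no measured pair shows what swapping the side chain does in this assay. With nothing to point in either direction, the expectation is a step of a 1.1-fold higher number from compound 3 to compound 4 (0.02 log units; within the scatter), which lies within the scatter. Compound 4 is therefore estimated at 0.9 h, with a range from 0.3 h to 3 h.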

Compound 4, half-life: 0.898 h
The estimate for compound 4 lay 1.0-fold (0.00 log units) above the measured number, within the range that was stated.
By their numbers in this assay, from the lowest: compound 2; then compounds 1, 3 and 4 (each within the scatter of the next).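

In this assay, among these compounds, exchanging 3-aminopropyl for carboxy on a saturated chain carbon, two bonds along the chain from an amine nitrogen and a carbonyl carbon, gives a 1.1-fold higher number from compound 3 to compound 4 (0.02 log units; within the scatter), and this is the first measured step that changes the amino acid side chain itself rather than the number of esters on the shared core. Compound 3 and compound 4 cannot be told apart on this read-out, so at this one place, a side chain ending in an amine and a side chain ending in a carboxy group give the same result as far as the scatter allows. No measured information is available to explain this result.

One pair cannot show whether the side chain at this place matters in general, so a plain methyl, a phenyl ring or a longer chain ending in a carboxylic acid on the same carbon could still give a different number. As far as these compounds go, it also remains open whether the same exchange would give a similar result with a second ester on the core, as in compound 1.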